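Methoxy in Place of Hydrogen on a Shared Core

The compounds below may be only part of what the source reports. "The series", "measured", "known", "first", "only" and "open" are said of these compounds alone.

Compound 1 `CN1C/C(=C\c2ccccc2)C(=O)[C@]2(C1)[C@@H](c1ccccc1)CN(C)[C@@]21C(=O)Nc2ccccc21` — in a functional assay on the whole organism (strain Wister albino) for inhibition, with Rattus norvegicus as the target, read by paw edema, with stated times of 1 h and 4 h, at a dose of 50 mg/kg by the intraperitoneal route (on this read-out higher numbers stand for more inhibition at the one dose given (going by the name of the read-out) and lower numbers for less inhibition), compound 1 gives 126%.
Compound 2 `CN1C/C(=C\c2ccccc2)C(=O)[C@]2(C1)[C@@H](c1ccccc1)CN(C)[C@@]21C(=O)N(C)c2ccccc21` — compound 2 gives 122%.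
Compound 3 `CN1C/C(=C\c2ccc(Br)cc2)C(=O)[C@]2(C1)[C@@H](c1ccc(Br)cc1)CN(C)[C@@]21C(=O)N(C)c2ccccc21` — compound 3 gives 82.8%.

Compound 1 stands highest of the three numbers. Nearest is compound 2: a number 4 percentage points lower from compound 1 to compound 2 (within the scatter), a step within the scatter, so the two cannot be placed in order. Furthest is compound 3, whose number is beyond the scatter below that of compound 1; compound 3 carries two bromines and a methyl that compound 1 lacks, so no single step connects them.

Compound 4 `COc1ccc(/C=C2\CN(C)C[C@@]3(C2=O)[C@@H](c2ccccc2)CN(C)[C@@]32C(=O)Nc3ccccc32)cc1` differs from compound 1 by methoxy in place of hydrogen on an aromatic carbon. Among the compounds with values here, no measured step bears directly on this: the only one available exchanges hydrogen for methyl on a ring nitrogen and stays within the scatter. The values of compound 2 and compound 3 show that two bromines on the aromatic rings go with a lower number, but that pair changes two places at once. A modest downward step, or none beyond the scatter, is therefore expected: a number 14 percentage points lower from compound 1 to compound 4 (beyond the scatter). For compound 4 the estimate in this assay is 112%, with a range from 80% to 135%.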

Compound 4, a percentage reported as inhibition, in the whole organism at one dose (the size of the read-out at that dose, not a potency): 139%
The estimate for compound 4 lay 27 percentage points below the measured number; measured number outside the range, above it.
By their numbers in this assay, from the lowest: compound 3; then compounds 2 and 1 (each within the scatter of the next); then compound 4.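

In this assay, within the data shown here, the change from phenyl to 4-methoxyphenyl gives a number 13 percentage points higher from compound 1 to compound 4 (beyond the scatter), the only single change that moves the number beyond the usual scatter. Among these compounds, it also shows that this aromatic carbon, para to a large group, can carry a methoxy group with the inhibition read-out going up rather than down, which the earlier compounds could not show, since the only single step among them concerned a ring nitrogen. Nothing measured here gives a reason for the rise.

Going by these compounds, how a hydroxy group, an amine or a carboxylic acid on this same carbon would compare with methoxy remains open. Also open, on these data alone, is whether methoxy would give a similar step on the core of compound 2, which has a methyl on the amide-type nitrogen.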